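The source may hold more compounds than are shown below. What is called first, only, known or untested is meant among the compounds shown, and "the series" means these compounds.

Measured compounds in this study:

compound 1 `CC(C)=CCC/C(C)=C/CC1Cc2c(OCCCNS(=O)(=O)c3ccc([N+](=O)[O-])cc3)cc(=O)n(CCCO)c2CC1(C)C`, 7.4%
compound 2 `CC(C)=CCC/C(C)=C/CC1Cc2c(OCCCNC(=O)c3cccs3)cc(=O)n(CCCO)c2CC1(C)C`, 72.8%
compound 3 `CC(C)=CCC/C(C)=C/CC1Cc2c(OCCCNC(=O)c3ccc([N+](=O)[O-])cc3)cc(=O)n(CCCO)c2CC1(C)C`, 16.8%

In a functional assay on PANC-1 cells (Homo sapiens) for inhibition, read by MTT assay, with a stated time of 24 h, tested at 10 uM (a higher number here means more inhibition at the concentration tested (going by the name of the read-out), a lower number less inhibition), compound 2 gives 72.8%, the highest of the three numbers. The step of a number 65.4 percentage points higher from compound 1 to compound 2 (beyond the scatter) and the step of a number 56 percentage points lower from compound 2 to compound 3 (beyond the scatter) are both large and beyond the scatter, while a number 9.4 percentage points higher from compound 1 to compound 3 (within the scatter) lies within it. So the group attached to the amine nitrogen decides most of what these three compounds show.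

Compound 4 `CC(C)=CCC/C(C)=C/CC1Cc2c(OC(=O)Nc3ccccc3F)cc(=O)n(CCCO)c2CC1(C)C` has not yet been measured. It differs from compound 2 in one place: (2-fluorophenyl)carbamoyl in place of 3-(((thiophen-2-yl)carbonyl)amino)propyl on an oxygen on an aromatic ring. Among the compounds with values here, none of the measured steps covers this change directly, since all of them alter only the group on the amine nitrogen and leave the propyl chain in place. The measured steps do show that the read-out in this assay can move by large amounts when the group near that oxygen changes. The expectation for compound 4 is therefore uncertain, and a step of a number 37.8 percentage points lower from compound 2 to compound 4 (beyond the scatter) downward is expected, with a wide range. Compound 4 is estimated at 35%, between 8% and 75%.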

Compound 4, a percentage reported as inhibition, at one concentration (the size of the read-out at that concentration, not a potency): 71.6%
Compound 4: the middle estimate sits 36.6 percentage points below what was measured, within the range that was stated.
By their numbers in this assay, from the lowest: compounds 1 and 3 (each within the scatter of the next); then compounds 4 and 2 (each within the scatter of the next).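

Exchanging 3-(((thiophen-2-yl)carbonyl)amino)propyl for (2-fluorophenyl)carbamoyl on an oxygen on an aromatic ring gives a number 1.2 percentage points lower from compound 2 to compound 4 (within the scatter) in this assay, so the two compounds cannot be told apart in this read-out. The earlier compounds shown here varied only the group on the amine nitrogen, with the propyl chain kept in place; this pair shows that neither that chain nor the thiophene ring is required for a number at this level, at least with the (2-fluorophenyl)carbamoyl group in their stead. The data offer nothing that explains why the two groups match here.

The compounds shown leave open whether the fluorine matters, since neither a plain phenylcarbamoyl nor a chlorine in its place appears among them. They also leave open how a (4-nitrophenyl)carbamoyl group or a longer chain between the oxygen and the carbamoyl would read in this assay.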